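A few compounds are considered here, and "the series" means these few. Any claim that something is new, unique, unknown or untested is made for them only; others in the source may bear on it.

Measured so far:
Compound 1 `N#Cc1ccc(N2CCC(C(=O)N3N=CC[C@H]3c3cc(F)cc(F)c3)CC2)nn1`; in a physicochemical assay for lipophilicity, read by HPLC, measured as chromatographic lipophilicity, at pH 7.4 (on this read-out lower numbers stand for lower lipophilicity and higher numbers for higher lipophilicity), compound 1 gives 4.8.
Compound 2 `O=C(c1ccccc1)N1CCC(C(=O)N2N=CCC2c2ccccc2)CC1`; in this assay compound 2 gives 4.4.

Of these two numbers, compound 2 stands lowest. For the measured compounds named here, its only neighbour is compound 1, which lies higher by an amount beyond the usual scatter of this kind of measurement, so the two compounds are clearly apart on this read-out. Going by the values given here, no pair of measured compounds differs in a single place, so there is no measured step to lean on for the next compound.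

Compound 3 `O=C(c1ccccn1)N1CCC(C(=O)N2N=CCC2c2ccccc2)CC1` is built from compound 2 by one change: pyridin-2-yl in place of phenyl on a carbonyl carbon. The rest of the molecule is untouched, so whatever compound 3 shows rests on pyridin-2-yl standing where phenyl stood on the carbonyl carbon.

Without a measured step of the same kind, the expectation rests on the change itself. Compound 3 is expected to come in at 3.7, within a range from 3.2 to 4.2. That estimate means a step of a number 0.70 log units lower from compound 2 to compound 3 (beyond the scatter), expected to be downward and beyond the scatter.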

Compound 3, distribution coefficient: 3.1
Estimate against measurement, compound 3: 0.60 log units above; measured number outside the range, below it.
By their numbers in this assay, from the lowest: compound 3; then compound 2; then compound 1.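

In this assay, the step from phenyl to pyridin-2-yl on a carbonyl carbon whose other neighbour is an amide-type nitrogen in a ring is a number 1.30 log units lower from compound 2 to compound 3 (beyond the scatter), the first single-place comparison available here. It shows that this position is sensitive to the ring it carries: the heavy-atom count stays the same, yet one ring carbon giving way to nitrogen, with one hydrogen-bond acceptor entering, moves the read-out by a large amount. Nothing shown here explains the size of this drop.

The compounds shown leave open whether pyridin-3-yl or pyridin-4-yl on the same carbonyl carbon would bring a step of similar size. They also leave open how a saturated ring such as cyclohexyl, or a phenyl ring carrying an amine, would read there.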